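The source may report more compounds than this note shows. Statements on the series, on what has been measured and on what is new or still open speak of the compounds shown alone.

Of the compounds shown here, three built on a shared core have been measured in an ADME assay on S9 fraction from liver (Rattus norvegicus) for metabolic stability, read by LC-MS, using NADPH, with a stated time of 30 min; a lower number here means that less of the compound is left, a higher number that more of the compound is left. There, compound 1 `CCCCCCCCc1ccc(OCC(=O)Cn2nnnc2-c2ccccc2)cc1` gives 36%, compound 2 `CCCCCCCCc1ccc(OCC(=O)Cn2nnnc2-c2ccc(Cl)cc2)cc1` gives 45% and compound 3 `CCCCCCCCc1ccc(OCC(=O)Cn2nnnc2-c2ccc(S(=O)(=O)N(C)C)cc2)cc1` gives 40%. The numbers do not separate these three, as the steps between them show: a number 9 percentage points higher from compound 1 to compound 2 (within the scatter), a number 4 percentage points higher from compound 1 to compound 3 (within the scatter) and a number 5 percentage points lower from compound 2 to compound 3 (within the scatter). Compound 3 therefore stands level with the other two, within the scatter of both.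

Compound 4 `CCCCCCCCc1ccc(OCC(=O)Cn2nnnc2-c2cccc(S(=O)(=O)N(C)C)c2)cc1` contains the same atoms as compound 3, joined differently: 3-(dimethylsulfamoyl)phenyl in place of 4-(dimethylsulfamoyl)phenyl on an aromatic carbon. The dimethylsulfamoyl group stays in the molecule, and only its place on the phenyl group differs. Among the measured compounds shown here, no measured pair shows a change of this kind, so the evidence is indirect. The nearest guides are the steps that bring in the dimethylsulfamoyl group, a number 4 percentage points higher from compound 1 to compound 3 (within the scatter) and a number 5 percentage points lower from compound 2 to compound 3 (within the scatter). Neither introducing this group nor exchanging it for chloro moved the number beyond the scatter, so no step beyond the scatter is expected in this assay from moving it. The estimated change is no change at the digits printed from compound 3 to compound 4 (within the scatter), with no direction favoured. Compound 4 is expected to give 40%, with an estimated range from 28% to 52%.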

Compound 4, percent of the compound remaining: 24%
Estimate against measurement, compound 4: 16 percentage points above; the whole stated range lies above it.
By their numbers in this assay, from the lowest: compound 4; then compounds 1, 3 and 2 (each within the scatter of the next).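

In this assay, among the compounds shown here, the place of the dimethylsulfamoyl group on the phenyl group makes a difference that the earlier compounds could not reveal: with the same atoms joined differently, the change from 4-(dimethylsulfamoyl)phenyl to 3-(dimethylsulfamoyl)phenyl gives a number 16 percentage points lower from compound 3 to compound 4 (beyond the scatter). In this new place, the group also stands apart from the hydrogen it replaces, with a number 12 percentage points lower from compound 1 to compound 4 (beyond the scatter), and from 4-chlorophenyl, with a number 21 percentage points lower from compound 2 to compound 4 (beyond the scatter), whereas 4-(dimethylsulfamoyl)phenyl stayed within the scatter of both comparisons. Nothing available explains why moving the group on the phenyl group leaves less of the compound.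

On these data alone, it remains open whether this lower number belongs to the dimethylsulfamoyl group itself or would also appear with another group, such as an amine or a carboxylic acid, in the place it holds in 3-(dimethylsulfamoyl)phenyl. Also open, as far as these compounds go, is whether the gap between the two placements would persist if a shorter chain replaced the long chain on the shared core.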